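The source may hold more compounds than are shown below. What is called first, only, known or untested is meant among the compounds shown, and "the series" means these compounds.

Series values in a functional assay on HCT-116 cells (Homo sapiens) for cytotoxicity, read by MTT assay, with a stated time of 48 h, in the presence of a further agent that is not named here; a higher number here means that more compound is needed for the effect, a lower number that less compound is needed:

- compound 1 `COc1ccc(-c2cc(NNC(=O)Nc3cc(Cl)nc(Cl)c3)nc3c2cnn3C)cc1`: 12300 nM
- compound 2 `COc1ccc(-c2cc(NNC(=O)Nc3cc(Cl)nc(Cl)c3)nc3c2c(C)nn3C)cc1`: 82300 nM
- compound 3 `Cn1ncc2c(-c3ccccc3)cc(NNC(=O)Nc3cc(Cl)nc(Cl)c3)nc21`: 6240 nM

Compound 1 cannot be separated from compound 3, with a 2.0-fold lower number from compound 1 to compound 3 (0.29 log units; within the scatter). Compound 2 stands apart, with a 6.7-fold higher number from compound 1 to compound 2 (0.83 log units; beyond the scatter).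

Compound 4 `COc1ccc(-c2cc(NNC(=O)Nc3cc(Br)nc(Br)c3)nc3c2cnn3C)cc1` is the next entry, and its difference from compound 1 is 2,6-dibromopyridin-4-yl in place of 2,6-dichloropyridin-4-yl on an amide-type nitrogen.

For the measured compounds named here, no measured step touches this group, so the data give no direct reading of the change. The two known steps both lie elsewhere in the structure. Hydrogen in place of methoxy gave a 2.0-fold lower number from compound 1 to compound 3 (0.29 log units; within the scatter), and methyl in place of hydrogen gave a 6.7-fold higher number from compound 1 to compound 2 (0.83 log units; beyond the scatter). These show only how far the numbers in this assay have moved so far, and the range is kept wide to reflect that.

No step beyond the scatter is expected, in either direction. The expected change is a 1.1-fold lower number from compound 1 to compound 4 (0.05 log units; within the scatter). For compound 4 the estimated value is 11000 nM, with an expected range from 4000 nM to 32000 nM.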

Compound 4, half-maximal effective concentration: 45200 nM
For compound 4 the middle estimate is 4.1-fold (0.61 log units) below the measured one; the measured number lies above the stated range.
By their numbers in this assay, from the lowest: compounds 3 and 1 (each within the scatter of the next); then compounds 4 and 2 (each within the scatter of the next).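

The 2,6-dichloropyridin-4-yl group on the amide-type nitrogen had not been varied before, and in this assay the exchange for 2,6-dibromopyridin-4-yl gives a 3.7-fold higher number from compound 1 to compound 4 (0.57 log units; beyond the scatter) on an otherwise unchanged structure. The number therefore responds to the halogen on this ring, and not only to changes elsewhere in the structure, even though the heavy-atom, donor and acceptor counts of the two groups are the same. No measured evidence on the origin of this shift is available.

Open questions remain at this ring, since the compounds shown carry only chlorine or bromine there, and fluorine or an amine in their place would show whether the trend extends. Going by these compounds, it also remains open whether the same exchange would shift the number similarly on the core of compound 3.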